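Debenzylation Across Two Cores: Expecting Compound 4

A few compounds are considered here, and "the series" means these few. Any claim that something is new, unique, unknown or untested is made for them only; others in the source may bear on it.

Compound 1 `COc1ccc(-c2sc(C(=O)O)cc2-c2cc(OC)c(OC)c(OC)c2)cc1OCc1ccccc1`: > 100000 nM (a limit)
Compound 2 `COc1ccc(-c2sc(C(=O)O)cc2-c2cc(OC)c(OC)c(OC)c2)cc1O`: 7510 nM
Compound 3 `COc1ccc(-c2ccsc2-c2cc(OC)c(OC)c(OC)c2)cc1OCc1ccccc1`: > 100000 nM (a limit)

In a functional assay on HT-1080 cells (Homo sapiens) for antiproliferative activity, read by MTT assay, with a stated time of 72 h (a lower number here means a stronger inhibitor, a higher number a weaker inhibitor), compound 1 and compound 3 are reported only as a limit, (the limit of > 100000 nM in this assay, at which 2 of the 3 values shown sit). Compound 2, in contrast, gives a number, 7510 nM. The change hydrogen in place of benzyl on an oxygen on an aromatic ring brought an at least 13-fold lower number from compound 1 to compound 2 (1.12 log units; beyond the scatter). Compound 4 `COc1ccc(-c2ccsc2-c2cc(OC)c(OC)c(OC)c2)cc1O` is not yet measured; it arises from compound 3 by hydrogen in place of benzyl on an oxygen on an aromatic ring, the same change as before, at a place described in the same words. The difference between the core of compound 1 and the core of compound 3 is not broken down here. Because compound 3 sits at the limit (the limit of > 100000 nM in this assay, at which 2 of the 3 values shown sit), the starting point is uncertain, so only a rough expectation is possible. Compound 4 is expected to show a step of an at least 3.3-fold lower number from compound 3 to compound 4 (0.52 log units; beyond the scatter) in this assay, by analogy with an at least 13-fold lower number from compound 1 to compound 2 (1.12 log units; beyond the scatter). Compound 4 is therefore estimated at 30000 nM, between 5000 nM and 200000 nM.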

Compound 4, half-maximal inhibitory concentration: 2120 nM
Compound 4: the middle estimate sits 14-fold (1.15 log units) above what was measured; measured number below the stated range.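

In this assay, the change from benzyloxy to hydroxy brought an at least 47-fold lower number from compound 3 to compound 4 (1.67 log units; beyond the scatter), so the direction of the step carried over from the core of compound 1 to the core of compound 3. Taken with the earlier step, the comparison reads: the same change on two cores in this assay, an at least 13-fold lower number (1.12 log units; beyond the scatter) from compound 1 to compound 2 and an at least 47-fold lower number (1.67 log units; beyond the scatter) from compound 3 to compound 4; the limit leaves it open whether they differ. Both steps start from a limit of the assay rather than a number, so the data show a shared direction on these two cores but no shared size.

The compounds shown leave open how an amine or an ethoxy group would read at this oxygen-bearing place on the ring. They also leave open whether the change would carry over to a core bearing an amide in place of the carboxylic acid.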